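From tert-butyl to methyl on the ester of compound 2

The source may hold more compounds than are shown below. What is called first, only, known or untested is meant among the compounds shown, and "the series" means these compounds.

In an ADME assay on N2a cells (Mus musculus) for cytotoxicity, read by MTT assay, with a stated time of 24 h (a higher number here means a weaker inhibitor, a lower number a stronger inhibitor), compound 1 `COc1cc(/C=C/C(=O)CC(=O)/C=C/c2cccc(C(F)(F)F)c2)ccc1O` gives 65700 nM as a measured number. Compound 2 `COc1cc(/C=C/C(=O)CC(=O)/C=C/c2ccc(OCC(=O)OC(C)(C)C)c(C(F)(F)F)c2)ccc1O` gives > 100000 nM here, which is a limit of the assay and not a number. Among the compounds with values here, the only measured step is an at least 1.5-fold higher number from compound 1 to compound 2 (0.18 log units; that floor lies within the scatter) on adding (tert-butoxycarbonyl)methoxy in place of hydrogen on an aromatic carbon. Compound 3 `COC(=O)COc1ccc(/C=C/C(=O)CC(=O)/C=C/c2ccc(O)c(OC)c2)cc1C(F)(F)F` differs from compound 2 by methyl in place of tert-butyl on an oxygen next to a carbonyl group with methyl in place of tert-butyl on an oxygen next to a carbonyl group. That measured step covers a different change, so no shift beyond the scatter is expected in this assay for this one. The expected step is an at least 1.1-fold lower number from compound 2 to compound 3 (0.04 log units; that floor lies within the scatter) by this estimate. Compound 3 is expected at 90000 nM with a range from 35000 nM to 200000 nM in this estimate.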

Compound 3, half-maximal inhibitory concentration: 38700 nM
Compound 3: the middle estimate sits 2.3-fold (0.37 log units) above what was measured, and the stated range covers the measured number.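

Changing only the ester, methyl in place of tert-butyl, gives the first shift beyond the scatter in this assay, with an at least 2.5-fold lower number from compound 2 to compound 3 (0.41 log units; beyond the scatter). Compound 2 sits at a limit of the assay, not a number, so that step is only a floor: the limit of > 100000 nM in this assay, at which 1 of the 3 values shown sits.

Set against the compound without the side chain, the methyl ester shows no shift beyond the scatter, with a 1.7-fold lower number from compound 1 to compound 3 (0.23 log units; within the scatter). On these data alone, how a carboxylic acid or an ethyl ester in place of the methyl ester would read in this assay stays open.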